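The compounds below may be only part of what the source reports. "The series", "measured", "known", "first", "only" and "open" are said of these compounds alone.

The measured compounds are compound 1 `COC(=O)C1=C(CN2CCOCC2=O)NC(c2nccs2)=NC1(C)c1ccc(F)cc1`, compound 2 `COC(=O)C1=C(CN2CCNC(=O)C2)NC(c2nccs2)=NC1(C)c1ccc(F)cc1` and compound 3 `COC(=O)C1=C(COC2CCOC2)NC(c2nccs2)=NC1(C)c1ccc(F)cc1`. In an ADME assay on microsomes from liver (Mus musculus) for metabolic stability, read by LC-MS, using NADPH, with stated times of 10 min and 30 min, tested at 1 uM (a lower number here means slower removal, a higher number faster removal of the compound), compound 1 gives 80 mL/min/kg, compound 2 gives 81 mL/min/kg and compound 3 gives 79 mL/min/kg. Compound 2 holds the highest of the three numbers, yet its distance to compound 1 and to compound 3 lies within the scatter, so no order can be read among them. Compound 4 `COC(=O)C1=C(COC(C(=O)O)C(F)(F)F)NC(c2nccs2)=NC1(C)c1ccc(F)cc1` differs from compound 2 as follows: a group of 9 heavy atoms (3 carbon, 3 oxygen, 3 fluorine; no ring) in place of a group of 7 heavy atoms (4 carbon, 2 nitrogen, 1 oxygen; one six-membered non-aromatic ring with 2 hetero atoms), on a saturated chain carbon bound to a double-bonded ring carbon. Two changes made at the same place, a 1.0-fold higher number from compound 1 to compound 2 (0.01 log units; within the scatter) and a 1.0-fold lower number from compound 2 to compound 3 (0.01 log units; within the scatter), both stayed within the scatter. On that basis the step of a 1.0-fold lower number from compound 2 to compound 4 (0.01 log units; within the scatter) is expected to stay within the scatter as well. Compound 4 is therefore estimated at 80 mL/min/kg, with a range from 45 mL/min/kg to 140 mL/min/kg.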

Compound 4, clearance: 24 mL/min/kg
Compound 4: middle estimate off by 3.3-fold (0.52 log units), on the high side, outside the stated range (below it).
By their numbers in this assay, from the lowest: compound 4; then compounds 3, 1 and 2 (each within the scatter of the next).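

In this assay this place proves sensitive to the group it carries: 1-carboxy-2,2,2-trifluoroethyl in place of oxolan-3-yl gives a 3.3-fold lower number from compound 3 to compound 4 (0.52 log units; beyond the scatter) and the same oxygen-linked group gives a 3.4-fold lower number from compound 2 to compound 4 (0.53 log units; beyond the scatter) and also a 3.3-fold lower number from compound 1 to compound 4 (0.52 log units; beyond the scatter) when it replaces the two six-membered rings. Going by these compounds alone, the earlier groups alone showed no such step on the saturated chain carbon. Nothing available explains this step. The compounds shown leave open whether the carboxylic acid or the trifluoromethyl accounts for it. They also leave open how an amine or a longer chain would read here.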